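Anilino to (4-Methylbenzyl)amino: An Expected Cytotoxicity Step

A few compounds are considered here, and "the series" means these few. Any claim that something is new, unique, unknown or untested is made for them only; others in the source may bear on it.

All measurements here come from a functional assay on SW480 cells (Homo sapiens) for cytotoxicity, read by MTT assay, with a stated time of 48 h; on this read-out lower numbers stand for stronger inhibition and higher numbers for weaker inhibition. Going by the values given here, compound 1 `CCOC(=O)C1(C(=O)Nc2ccc(F)cc2)CC1c1cc(OC)c(OC)c(OC)c1` is the only member of the set with a number in this assay: compound 1 gives 46700 nM; 42000 nM (2 entries), two entries that agree closely (the several entries of compound 1 in this assay, 46700 nM; 42000 nM (2 entries)). Compound 2 `CCOC(=O)[C@]1(C(=O)Nc2ccccc2)C[C@H]1c1cc(OC)c(OC)c(OC)c1` reaches only the limit of the assay, > 100000 nM. Compound 3 `COc1cc([C@H]2C[C@@]2(CO)C(=O)Nc2ccccc2)cc(OC)c1OC` likewise gives only the assay limit, > 100000 nM. So compound 3 stands at the weak end of what was measured, one of the two of three values that sit at the limit (the limit of > 100000 nM in this assay, at which 2 of the 3 values shown sit); no single number is known for it, and no step between measured compounds connects it to any other. Compound 4 `COc1cc([C@H]2C[C@@]2(CO)C(=O)NCc2ccc(C)cc2)cc(OC)c1OC` differs from compound 3 by one change: 4-methylbenzyl in place of phenyl on an amide-type nitrogen. Cut one bond further out, this reads anilino to (4-methylbenzyl)amino. Nothing in the measured set shows how such a change acts in this assay, and the starting point is itself a limit. The step expected from compound 3 to compound 4 is therefore a number no higher from compound 3 to compound 4 (the limit leaves the size open), none beyond the scatter. Compound 4 is expected to give 100000 nM, within 30000 nM to 300000 nM, and most likely to be reported again only as a limit.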

Compound 4, half-maximal inhibitory concentration: > 100000 nM
Compound 4: only a limit was reported (the forecaster's own chance of this, stated with the estimate: 60%); the middle value lies on the limit itself.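

Compound 3 and compound 4 both stop at a limit in this assay, not at a number, so no step between them can be read: the limit of > 100000 nM in this assay, at which 3 of the 4 values shown sit.

From the compounds shown here alone, whether 4-methylbenzyl in place of phenyl on an amide-type nitrogen shifts cytotoxicity at all, and by how much, stays open.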